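The source may hold more compounds than are shown below. What is called first, only, known or untested is meant among the compounds shown, and "the series" means these compounds.

Compound 1 `O=C(/C=C\Nc1ccc(F)cc1)c1nc(-c2ccc(F)cc2)n2ccccc12` gives > 30000 nM in a functional assay on HCT-116 cells (Homo sapiens) for cytotoxicity, read by MTT assay, with a stated time of 48 h (a lower number here means a stronger inhibitor, a higher number a weaker inhibitor), a limit of the assay rather than a number.
Compound 2 `COc1ccc(N/C=C\C(=O)c2nc(-c3ccc(C(F)(F)F)cc3)n3ccccc23)cc1OC` gives > 30000 nM in this assay, again a limit.
Compound 3 `COc1ccc(N/C=C\C(=O)c2nc(-c3ccc(F)cc3)n3ccccc23)cc1` gives > 30000 nM in this assay, also a limit.

Compound 3 therefore stands at the edge of what this assay can report, and none of the three measured compounds does anything different. Within the data shown here, the single measured change, a step that the two limits leave unreadable from compound 1 to compound 3, cannot be read in size or direction because of the limit of > 30000 nM in this assay, at which 3 of the 3 values shown sit. Compound 4 `COc1ccc(N/C=C\C(=O)c2nc(-c3ccc(F)cc3)n3ccccc23)cc1OC` differs from compound 3 by methoxy in place of hydrogen on an aromatic carbon. Among the measured compounds shown here, compound 2 carries the same 3,4-dimethoxyphenyl group and sits at the limit as well, so the added methoxy has not yet been seen to pull any compound into the measurable range. For the measured compounds named here, no step bears on the change in a readable way, so no step beyond the scatter is expected, and the move from compound 3 to compound 4 is estimated as a number no higher from compound 3 to compound 4 (the limit leaves the size open). Compound 4 is thus expected to give about 30000 nM, within 10000 nM to 100000 nM, most likely again as a limit.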

Compound 4, half-maximal inhibitory concentration: > 30000 nM
Compound 4 ended at the assay's limit; the forecaster's own chance of this, stated with the estimate: 80%; the middle value lies on the limit itself.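

The steps to compound 4 from compound 1, compound 2 and compound 3 cannot be read in size or direction, because all four compounds sit at the same limit: the limit of > 30000 nM in this assay, at which 4 of the 4 values shown sit.

The compounds shown leave open which change, if any, would give a measurable value in this assay.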